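Propoxy to trifluoromethoxy on the pendant aryl ring

A few compounds are considered here, and "the series" means these few. Any claim that something is new, unique, unknown or untested is made for them only; others in the source may bear on it.

Compound 1 `C=Cc1cccc(-c2[nH]c3cc(OC)ccc3c(=O)c2C(=O)OCC)c1` carries a vinyl group on the aryl ring attached to the shared core. In an ADME assay on HEK293 cells (Homo sapiens) for cytotoxicity, read by luminescence, with a stated time of 72 h (on this read-out higher numbers stand for an effect only at larger amounts of compound and lower numbers for an effect already at smaller amounts), compound 1 gives > 22000 nM, which is a limit of the assay and not a number. Compound 2 `CCCOc1cccc(-c2[nH]c3cc(OC)ccc3c(=O)c2C(=O)OCC)c1` has propoxy in place of vinyl on an aromatic carbon; in this assay compound 2 gives > 22000 nM, again a limit. The step that the two limits leave unreadable from compound 1 to compound 2 is therefore not readable in size, and the limit of > 22000 nM in this assay, at which 2 of the 2 values shown sit, is all the series offers so far. Compound 3 `CCOC(=O)c1c(-c2cccc(OC(F)(F)F)c2)[nH]c2cc(OC)ccc2c1=O` is the next member: trifluoromethyl in place of propyl on an oxygen on an aromatic ring. Within the data shown here, no measured step bears on this change with a readable size, so nothing beyond the scatter is expected; the expected step is a step that the limit leaves unreadable from compound 2 to compound 3. Compound 3 is accordingly estimated at 30000 nM, with a range from 10000 nM to 100000 nM, and most likely returned once more as a limit.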

Compound 3, half-maximal effective concentration: > 22000 nM
Compound 3 was reported as a limit; the forecaster's own chance of this, stated with the estimate: 80%; the middle value does not contradict the limit.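

Among these compounds, compound 3 gives > 22000 nM in this assay, a limit and not a number, so no step among compound 1, compound 2 and compound 3 can be read. The compounds shown leave open how vinyl, propoxy and trifluoromethoxy on the aryl ring compare in this assay: the limit of > 22000 nM in this assay, at which 3 of the 3 values shown sit.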